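The source may report more compounds than this note shows. Statements on the series, on what has been measured and on what is new or still open speak of the compounds shown alone.

Measured so far:
- compound 1, `Cc1nn(-c2ncnc3nc[nH]c23)c2c1C(OCc1ccc(Cl)cc1Cl)CC(=O)N2`: 4 nM
- compound 2, `Cc1nn(-c2ncnc3nc[nH]c23)c2c1C(OCc1ccccc1C#N)CC(=O)N2`: 8 nM

In a functional assay on HEK293 cells for agonist activity at G-protein coupled receptor 39 (Homo sapiens), read by scintillation proximity assay and inositol phosphate accumulation, with a stated time of 75 min, in the presence of a further agent that is not named here (on this read-out higher numbers stand for an effect only at larger amounts of compound and lower numbers for an effect already at smaller amounts), compound 2 gives 8 nM, the higher of the two numbers obtained so far; its nearest neighbour is compound 1, and the step of a 2.0-fold higher number from compound 1 to compound 2 (0.30 log units; within the scatter) lies within the scatter, so the two values show no real separation.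

Compound 3, `Cc1nn(-c2ncnc3nc[nH]c23)c2c1C(OCc1ccc(C(C)C)cc1)CC(=O)N2`, has not yet been measured. It differs from compound 2 by 4-isopropylphenyl in place of 2-cyanophenyl on a saturated chain carbon bound to an oxygen on a saturated carbon. For the measured compounds named here, the only measured step that bears on this position is the one from compound 1 to compound 2, in which exchanging one substituted phenyl for another on the same benzylic carbon left the number essentially unchanged. That step is the whole of the evidence, and it suggests that the aryl group on this chain can be varied without a large shift, but it says nothing specific about an isopropyl substituent, so the direction of any effect is open.

Compound 3 is therefore estimated to give a number close to compound 2, the expected step of a 1.5-fold higher number from compound 2 to compound 3 (0.18 log units; within the scatter) being small relative to the scatter, with an estimate of 12 nM and a range from 3 nM to 50 nM.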

Compound 3, half-maximal effective concentration: 5 nM
For compound 3 the middle estimate is 2.4-fold (0.38 log units) above the measured one, within the range that was stated.
By their numbers in this assay, from the lowest: compounds 1, 3 and 2 (each within the scatter of the next).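

In this assay, the change to 4-isopropylphenyl on a saturated chain carbon bound to an oxygen on a saturated carbon gives a 1.6-fold lower number from compound 2 to compound 3 (0.20 log units; within the scatter) and, against the dichlorinated compound, a 1.3-fold higher number from compound 1 to compound 3 (0.10 log units; within the scatter), so all three numbers remain within the scatter of one another. The earlier pair showed this tolerance only for a 2,4-dichlorophenyl and a 2-cyanophenyl group, whereas compound 3 extends it to a group with a different substituent and a different substitution pattern, made up of carbon alone and with no hydrogen-bond acceptor in place of the single acceptor of the 2-cyanophenyl group. No measurement is available that would explain why these exchanges leave the number within the scatter.

On these data alone, all three compounds carry a substituted phenyl group on this chain, so it remains open whether an unsubstituted phenyl group, or a plain butyl chain in place of the aryl group, would keep the number in the same range. It is equally open whether an amine or a carboxylic acid on the phenyl ring would be accommodated as readily as the groups shown here.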